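Ring swap on the shared core: pyrrole to isothiazole

A few compounds are considered here, and "the series" means these few. Any claim that something is new, unique, unknown or untested is made for them only; others in the source may bear on it.

Three compounds of this series have been run in a functional assay for activation of Alpha-1B adrenergic receptor (Homo sapiens), read by calcium flux; on this read-out lower numbers stand for an effect already at smaller amounts and higher numbers for an effect only at larger amounts of compound. Compound 1 `c1cnc(-c2ccccc2OCC2=NCCN2)nc1` returns only a limit of the assay, < 100000 nM, so it gives no number. Compound 2 `c1ccc(-c2cnccn2)c(OCC2=NCCN2)c1` gives 631 nM in this assay, and compound 3 `c1c[nH]c(-c2ccccc2OCC2=NCCN2)c1` gives 1 nM, the lowest number shown, with compound 2 the nearest. Within the data shown here, the step of a 630-fold lower number from compound 2 to compound 3 (2.80 log units; beyond the scatter) is the one readable step; the steps a step that the limit leaves unreadable from compound 1 to compound 2 and a step that the limit leaves unreadable from compound 1 to compound 3 stay unreadable because of the limit of < 100000 nM in this assay, at which 1 of the 3 values shown sits.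

The next compound, compound 4 `c1ccc(-c2ccns2)c(OCC2=NCCN2)c1`, differs from compound 3 in one place: 1,2-thiazol-5-yl in place of 1H-pyrrol-2-yl on an aromatic carbon. Among the measured compounds shown here, only the step from compound 2 to compound 3 bears on this change, and it was large in this assay. Compound 4 again carries a ring with 0 hydrogen-bond donors and 2 hydrogen-bond acceptors, as compound 2 does, while keeping the five-membered ring size of compound 3; a step part of the way back toward compound 2 is therefore expected. For compound 4 the estimate is 60 nM, between 5 nM and 800 nM, meaning an expected step of a 60-fold higher number from compound 3 to compound 4 (1.78 log units; beyond the scatter).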

Compound 4, half-maximal effective concentration: 12.6 nM
For compound 4 the middle estimate is 4.8-fold (0.68 log units) above the measured one; the range from low to high includes it.
By their numbers in this assay, from the lowest: compound 3; then compound 4; then compound 2.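

Compound 4 shows that a five-membered ring with 0 hydrogen-bond donors can still give a low number in this assay on this aromatic carbon, although the change from 1H-pyrrol-2-yl carries a cost (a 13-fold higher number from compound 3 to compound 4 (1.10 log units; beyond the scatter)). Pyrazin-2-yl and 1,2-thiazol-5-yl have the same donor and acceptor counts, yet they differ widely (a 50-fold lower number from compound 2 to compound 4 (1.70 log units; beyond the scatter)), so among these compounds those counts alone do not set the number. The steps from compound 1 cannot be read, and compound 1 gives only a limit (the limit of < 100000 nM in this assay, at which 1 of the 4 values shown sits).

As far as these compounds go, whether the step away from compound 3 follows the loss of the ring hydrogen-bond donor or the entry of sulfur stays open. Thiophen-2-yl and 1H-imidazol-2-yl at this place would bear on that question.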